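The source may hold more compounds than are shown below. What is called first, only, known or untested is meant among the compounds shown, and "the series" means these compounds.

Working notes on the series. In a functional assay on SH-SY5Y cells (Homo sapiens) for cytotoxicity, read by MTT assay, with a stated time of 72 h (on this read-out lower numbers stand for stronger inhibition and higher numbers for weaker inhibition), compound 1 `CN1CCN(CCCCCCn2c3c(c4ccccc42)C(=O)c2c[n+]([O-])c4ccccc4c2C3=O)CC1` gives 920 nM. Compound 2 `O=C1c2c[n+]([O-])c3ccccc3c2C(=O)c2c1c1ccccc1n2Cc1cn([C@H]2C[C@H](O)[C@@H](CO)O2)nn1` gives 620 nM in this assay, the smaller of the two numbers, though its gap to compound 1 lies within the scatter. Compound 3 `CC1(C)OCC(Cn2cc(Cn3c4c(c5ccccc53)C(=O)c3c[n+]([O-])c5ccccc5c3C4=O)nn2)O1` carries the change ((2,2-dimethyl-1,3-dioxolan-4-yl)methyl in place of 4-hydroxy-5-(hydroxymethyl)oxolan-2-yl on an aromatic nitrogen); the group that leaves has 2 hydrogen-bond donors and 3 defined stereocentres, the group that enters has none. Going by the values given here, no measured pair shows this change. The step from compound 2 to compound 3 in this assay is expected to be a 1.3-fold higher number from compound 2 to compound 3 (0.11 log units; within the scatter), no step beyond the scatter in either direction. Compound 3 is estimated at 800 nM in this assay, within 300 nM to 2200 nM.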

Compound 3, half-maximal inhibitory concentration: 230 nM
Compound 3: the middle estimate sits 3.5-fold (0.54 log units) above what was measured; measured number below the stated range.
By their numbers in this assay, from the lowest: compound 3; then compounds 2 and 1 (each within the scatter of the next).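

In this assay the step of a 2.7-fold lower number from compound 2 to compound 3 (0.43 log units; beyond the scatter) comes with (2,2-dimethyl-1,3-dioxolan-4-yl)methyl in place of 4-hydroxy-5-(hydroxymethyl)oxolan-2-yl, showing that the group on this aromatic nitrogen can move the number beyond the scatter. The lower number comes with an entering group that has 0 hydrogen-bond donors and no defined stereocentres. No available measurement explains this step.

This single pair does not separate the donors, the stereocentres and the ring itself. The compounds shown also leave open how a simple benzyl group or the opened 2,3-dihydroxypropyl chain would read at this position.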